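The compounds below may be only part of what the source reports. "The series", "measured", "known", "first", "only" and "open" are said of these compounds alone.

In an ADME assay on the whole organism (plasma) for pharmacokinetics, with Rattus norvegicus as the target, at a dose of 2 mg/kg by the oral route (on this read-out lower numbers stand for lower exposure and higher numbers for higher exposure at the dose given), compound 1 (`COc1ccc2c(c1)CC(c1nc3ccc(-c4ccnc(N)n4)cc3[nH]1)CO2`) gives 710 ng.h/mL, the higher of the two measured numbers and beyond the scatter from compound 2 (`Nc1nccc(-c2ccc3nc(C4COc5c(cccc5C(=O)NC5CC5)C4)[nH]c3c2)n1`), which gives 4.27 ng.h/mL. Compound 3 (`CN(C)CCCNC(=O)c1ccc2c(c1)CC(c1nc3ccc(-c4ccnc(N)n4)cc3[nH]1)CO2`) carries (3-(dimethylamino)propyl)carbamoyl in place of methoxy on an aromatic carbon. Among the compounds with values here, no measured step isolates this change. Within the data shown here, the only guide is compound 2, which also bears an amide and sits at 4.27 ng.h/mL. A fall beyond the scatter is therefore expected, with an estimated 20-fold lower number from compound 1 to compound 3 (1.31 log units; beyond the scatter). The expected value for compound 3 is 35 ng.h/mL, with an estimated range of 5 ng.h/mL to 250 ng.h/mL.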

Compound 3, area under the concentration-time curve: 4.72 ng.h/mL
The estimate for compound 3 lay 7.4-fold (0.87 log units) above the measured number, and the stated range ends above it.
By their numbers in this assay, from the lowest: compounds 2 and 3 (each within the scatter of the next); then compound 1.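

In this assay, within the data shown here, (3-(dimethylamino)propyl)carbamoyl in place of methoxy on an aromatic carbon gives a 150-fold lower number from compound 1 to compound 3 (2.18 log units; beyond the scatter) and this is the first measured step at this position. Exposure at the dose given therefore depends strongly on the group carried here, at least for this one exchange. Nothing measured bears on the reason for the fall.

The compounds shown leave open whether the fall goes with the carbamoyl link or with the dimethylamino end of the chain. Methylcarbamoyl or a carboxylic acid on this carbon would begin to separate the two.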